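The source may report more compounds than this note shows. Statements on the series, on what has been measured and on what is new or still open speak of the compounds shown alone.

Series notes. Compound 1 `CCCCNc1nc(N)nc2c1CN(Cc1ccccc1)CC2` holds the lowest number of the two measured in an assay on HEK293 cells for agonist activity at Toll-like receptor 8 (Homo sapiens), read by a luciferase reporter, with a stated time of 6 h; on this read-out higher numbers stand for an effect only at larger amounts of compound and lower numbers for an effect already at smaller amounts: compound 1 gives 0.06 uM. Compound 2 `CCCCNc1nc(N)nc2c1CCNC2` gives 0.6 uM in this assay, a higher number, beyond the scatter. Compound 3 `CCCCNc1nc(N)nc2c1CN(C(=O)c1ccccc1)CC2` is not yet measured; it differs from compound 1 by benzoyl in place of benzyl on an amine nitrogen in a ring. Among the measured compounds shown here, no measured pair shows what benzoyl in place of benzyl on the amine nitrogen in the ring does, so the direction is uncertain. Compound 3 is expected to show a modest rise in its number in this assay, a step of a 3.3-fold higher number from compound 1 to compound 3 (0.52 log units; beyond the scatter). The estimate for compound 3 is 0.2 uM, with a range from 0.04 uM to 1 uM.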

Compound 3, minimum effective concentration: 1.4 uM
The estimate for compound 3 lay 7.0-fold (0.85 log units) below the measured number; the whole stated range lies below it.
By their numbers in this assay, from the lowest: compound 1; then compound 2; then compound 3.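

In this assay the change from benzyl to benzoyl on an amine nitrogen in a ring gives a 23-fold higher number from compound 1 to compound 3 (1.37 log units; beyond the scatter) and is a large step. The six-membered aromatic ring of carbon stays in place, so this position clearly separates two groups that differ by a carbonyl. Nothing available bears on the reason for this step.

From the compounds shown here alone, it remains open whether a phenethyl group would keep the number of compound 1. Going by these compounds, it also remains open whether an acetyl or methanesulfonyl group on the same nitrogen would follow compound 3.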